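Sulfonamide series at the human serotonin 6 receptor: compound 4

The source may report more compounds than this note shows. Statements on the series, on what has been measured and on what is new or still open speak of the compounds shown alone.

Measured so far:
- compound 1 `O=C1c2[nH]nc(NS(=O)(=O)c3ccc4ccccc4c3)c2CCN1CC1CCNCC1` — 94.1%
- compound 2 `CC(C)Cc1cc(CNS(=O)(=O)c2ccc(C(C)(C)C)cc2)nn1-c1ccccc1` — 51.1%
- compound 3 `CC(C)Cc1cc(CNS(=O)(=O)Cc2cccc3ccccc23)nn1-c1ccccc1` — 28.7%

The read-out throughout is an assay on isolated protein for binding affinity to 5-hydroxytryptamine receptor 6 (Homo sapiens), tested at 10 uM; on this read-out higher numbers stand for more inhibition at the one concentration tested (going by the name of the read-out) and lower numbers for less inhibition. On the three numbers in hand, compound 2 stands second of three: compound 1 sits higher and compound 3 lower, and both gaps lie beyond the usual scatter of this assay. Among the compounds with values here, compound 2 and compound 3 share the same core and differ only on the sulfonyl side, yet no single-place step between them is counted here, so only their two values are compared.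

Compound 4 `CC(C)Cc1cc(CNS(=O)(=O)c2c(Cl)cccc2Cl)nn1-c1ccccc1` is the next member and has not been measured. It differs from compound 2 in one place: 2,6-dichlorophenyl in place of 4-(tert-butyl)phenyl on a sulfonyl sulfur. Within the data shown here, no step between measured compounds isolates the effect of such a swap, so the expectation rests on compound 2 alone, whose value of 51.1% is the nearest anchor. A modest downward step is expected, of a size that may not clear the scatter: a number 11.1 percentage points lower from compound 2 to compound 4 (beyond the scatter). For compound 4 the estimate in this assay is 40%, with a range from 15% to 70%, and the result will settle it.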

Compound 4, a percentage reported as inhibition, at one concentration (the size of the read-out at that concentration, not a potency): 59.4%
For compound 4 the middle estimate is 19.4 percentage points below the measured one; measured number inside the range.
By their numbers in this assay, from the lowest: compound 3; then compounds 2 and 4 (each within the scatter of the next); then compound 1.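

In this assay the series now has its first single-place step, on a sulfonyl sulfur, and it reads a number 8.3 percentage points higher from compound 2 to compound 4 (within the scatter) for 2,6-dichlorophenyl in place of 4-(tert-butyl)phenyl. At this place, then, the assay does not separate the two aryl groups, even though one carries only carbon in its 10 heavy atoms and the other carries 2 chlorine among its 8, and neither adds a hydrogen-bond donor, an acceptor or a net charge. Nothing measured on these compounds speaks to why the two groups read alike.

Within the data shown here, this single step covers only two substituted phenyl groups on the shared core, so it gives no general rule for the sulfonyl position. Open questions are how a phenyl ring bearing a single chlorine, a primary amine or a carboxylic acid would read at this sulfur, and whether a pyridine ring in place of the phenyl ring would leave the number where these two groups put it.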